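The compounds below may be only part of what the source reports. "The series", "measured", "known", "first", "only" and "open" are said of these compounds alone.

Working notes on the series. a functional assay on MV4-11 cells (Homo sapiens) for antiproliferative activity, with a stated time of 6 days, tested at 6.25 uM (a lower number here means a weaker effect, a higher number a stronger effect of the compound at the concentration tested), is the only read-out in hand. Compound 1 `CNC(=O)N1CCCc2ccc(NC(=O)c3ccc(-c4cc[nH]n4)cc3)cc21` gives 99.1% in this assay. Compound 2 `CNC(=O)N1CCCc2ccc(NC(=O)c3cccc(-c4ccccc4)c3)cc21` gives 1.39%, and compound 3 `CNC(=O)N1CCCc2ccc(NC(=O)c3cccc(-c4cnn(C)c4)c3)cc21` gives 93.5%. On these three numbers compound 1 stands at the top, with compound 3 within the usual scatter of it and compound 2 far beyond the scatter below it.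

The next compound, compound 4 `CNC(=O)N1CCCc2ccc(NC(=O)c3ccc(-c4cnn(C)c4)cc3)cc21`, is not yet measured in this assay. Against compound 1 the change is 1-methyl-1H-pyrazol-4-yl in place of 1H-pyrazol-3-yl on an aromatic carbon. Among the measured compounds shown here, the only measured step that bears on it is a number 92.1 percentage points higher from compound 2 to compound 3 (beyond the scatter), which brings the entering 1-methyl-1H-pyrazol-4-yl into the series and shows it paired with a high percentage of inhibition, though there it replaces phenyl rather than 1H-pyrazol-3-yl, and at a different place on the ring. For the measured compounds named here, no measured step compares 1H-pyrazol-3-yl with 1-methyl-1H-pyrazol-4-yl directly.

Since compound 1 already gives 99.1% and compound 3 carries the entering group at 93.5%, no step beyond the scatter is expected in this assay; the expected step is a number 4.1 percentage points lower from compound 1 to compound 4 (within the scatter). Compound 4 is therefore estimated at 95%, in the range 80% to 100%.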

Compound 4, a percentage reported as inhibition, at one concentration (the size of the read-out at that concentration, not a potency): 94.4%
Compound 4: the middle estimate sits 0.6 percentage points above what was measured; the measured number falls inside the stated range.
By their numbers in this assay, from the lowest: compound 2; then compounds 3, 4 and 1 (each within the scatter of the next).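

Among the compounds shown here, on the aromatic carbon para to a large group, the first direct comparison of these two five-membered rings in this assay gives a number 4.7 percentage points lower from compound 1 to compound 4 (within the scatter) and is the only step in hand at this position. The exchange goes from 1 hydrogen-bond donor in 1H-pyrazol-3-yl to 0 hydrogen-bond donors in 1-methyl-1H-pyrazol-4-yl, so for this pair a high percentage of inhibition at the tested concentration does not rest on that donor. No measurement in hand accounts for the two groups reading alike.

As far as these compounds go, both compounds lie close to the top of the percentage scale at a single concentration, so this read-out gives no potency for either, and whether compound 1 and compound 4 would separate at lower concentrations remains open. Also open, from the compounds shown here alone, is what phenyl, a morpholine, a primary amine or a carboxylic acid would give on this same carbon, and whether a pyrazole is needed here at all.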